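The source may report more compounds than this note shows. Statements on the series, on what has been measured and on what is new or still open speak of the compounds shown alone.

In a functional assay (Homo sapiens) (on this read-out higher numbers stand for weaker inhibition and lower numbers for stronger inhibition), three compounds have been measured so far. Compound 1 `Nc1nc2ccnc(-c3cccc(C=O)c3)n2n1` gives 700 nM, the lowest number of the three and therefore the strongest inhibition seen in this set. Compound 2 `CC(=O)Nc1nc2ccnc(-c3cccc(NS(=O)(=O)c4ccc(C)cc4)c3)n2n1` gives 1600 nM, a higher number that lies beyond the usual scatter of repeated measurements. Compound 3 `Cc1cnc(-c2cccc([N+](=O)[O-])c2)n2nc(N)nc12` gives 8700 nM, the highest number of the three, again well beyond the scatter. These three compounds differ from one another in several places at once, so none of the gaps between them can be tied to a single structural change.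

Compound 4 `Nc1nc2ccnc(-c3cccc(C(Cl)Cl)c3)n2n1` has not yet been measured. It differs from compound 1 in one place: dichloromethyl in place of formyl on an aromatic carbon. Among the compounds with values here, no pair of measured compounds shows what this kind of change does in this assay, so the expectation rests on the value of compound 1 alone. The expected step is a 1.7-fold higher number from compound 1 to compound 4 (0.23 log units; within the scatter), most likely small and toward a somewhat higher number. Compound 4 is estimated at 1200 nM, with a range from 400 nM to 4000 nM.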

Compound 4, half-maximal inhibitory concentration: 1000 nM
Beside the measured number, compound 4's estimate is 1.2-fold (0.08 log units) above it; the range from low to high includes it.
By their numbers in this assay, from the lowest: compounds 1, 4 and 2 (each within the scatter of the next, the first and the last beyond it); then compound 3.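

In this assay, putting dichloromethyl in place of formyl on this aromatic carbon gives a 1.4-fold higher number from compound 1 to compound 4 (0.15 log units; within the scatter) and so leaves the two compounds indistinguishable on this read-out. Within the data shown here, this is the first comparison in the set that changes only one place. It shows that, at this position, a group with a carbon-oxygen double bond and a hydrogen-bond acceptor can give way to a larger group with two chlorine atoms and neither of those features, without a step beyond the scatter. Nothing available here gives a reason for this result.

As far as these compounds go, whether other groups at this position, such as a carboxylic acid, an amine or a longer chain, would also stay within the scatter remains open. One step also cannot show whether this swap would behave the same way on another core.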